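A few compounds are considered here, and "the series" means these few. Any claim that something is new, unique, unknown or untested is made for them only; others in the source may bear on it.

Measured compounds:
compound 1 `COc1cc2c(cc1OC)C(CC(=O)O)CC2` — 27.5%
compound 2 `COc1cc2c(cc1OC)C(CC(=O)Nc1cccc(Cl)c1)CC2` — 24.6%
compound 3 `COc1cc2c(cc1OC)C(CC(=O)Nc1ccc(Cl)cc1)CC2` — 60.9%

In a functional assay on the whole organism (strain Wistar) for inhibition, with Rattus norvegicus as the target, read by paw edema, with a stated time of 3 h, at a dose of 100 mg/kg (on this read-out higher numbers stand for more inhibition at the one dose given (going by the name of the read-out) and lower numbers for less inhibition), compound 3 gives the highest of the three numbers. The step of a number 33.4 percentage points higher from compound 1 to compound 3 (beyond the scatter) and the step of a number 36.3 percentage points higher from compound 2 to compound 3 (beyond the scatter) are both large and beyond the scatter, whereas the step of a number 2.9 percentage points lower from compound 1 to compound 2 (within the scatter) stays within it. Compound 4 `COc1cc2c(cc1OC)C(CC(=O)Nc1ccccc1C)CC2` is not yet measured. It differs from compound 3 in one place: 2-methylphenyl in place of 4-chlorophenyl on an amide-type nitrogen. Among the measured compounds shown here, no measured pair shows a methyl-bearing ring on the amide-type nitrogen, so the only guide is the step of a number 36.3 percentage points higher from compound 2 to compound 3 (beyond the scatter), which shows that the pattern of the ring on that nitrogen alone can move the read-out a long way in either direction. Since the 4-chlorophenyl is given up, compound 4 is expected to fall back toward the level of compound 1 and compound 2, with the step of a number 27.9 percentage points lower from compound 3 to compound 4 (beyond the scatter) as the estimate. Compound 4 is therefore expected to give about 33% in this assay, within a range from 15% to 58%.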

Compound 4, a percentage reported as inhibition, in the whole organism at one dose (the size of the read-out at that dose, not a potency): 26.1%
Estimate against measurement, compound 4: 6.9 percentage points above; the measured number falls inside the stated range.
By their numbers in this assay, from the lowest: compounds 2, 4 and 1 (each within the scatter of the next); then compound 3.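

In this assay, 2-methylphenyl in place of 4-chlorophenyl on the amide-type nitrogen gives a number 34.8 percentage points lower from compound 3 to compound 4 (beyond the scatter), so a second ring pattern now fails to match the high reading of the 4-chlorophenyl amide. Against the 3-chlorophenyl amide there is a number 1.5 percentage points higher from compound 2 to compound 4 (within the scatter), and against the free acid there is a number 1.4 percentage points lower from compound 1 to compound 4 (within the scatter), which shows that an amide bearing a substituted phenyl does not by itself raise the read-out: among the three rings shown, only 4-chlorophenyl stands apart. Nothing measured here accounts for that difference.

The compounds shown change the ring's substituent and its place together, so the effect of each cannot be separated. The 2-chlorophenyl and 4-methylphenyl amides would pull the two apart, and the unsubstituted phenyl amide would give a plain reference.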